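A few compounds are considered here, and "the series" means these few. Any claim that something is new, unique, unknown or untested is made for them only; others in the source may bear on it.

Notes on the series. The common core carries a thiosemicarbazone arm; compound 1 `CC1=CC[C@H](C(C)(C)NC(=S)N/N=C/c2cccc(Cl)c2)CC1` has a 3-chlorophenyl on the carbon with a double bond to nitrogen, and in a functional assay on NCI-H460 cells (Homo sapiens) for inhibition, read by sulforhodamine B assay, with a stated time of 48 h (on this read-out lower numbers stand for stronger inhibition of growth and higher numbers for weaker inhibition of growth), compound 1 gives 1400 nM. Within the data shown here, compound 2 `CC1=CC[C@H](C(C)(C)NC(=S)N/N=C/c2ccco2)CC1` swaps that aryl for a furan, and in this assay compound 2 gives 13500 nM; the change a 9.6-fold higher number from compound 1 to compound 2 (0.98 log units; beyond the scatter) is the only measured step with one change. Compound 3 `CC1=CC[C@H](C(C)(C)NC(=S)N/N=C(\C)c2ccccc2)CC1` puts a methyl on the imine carbon with a plain phenyl. In this assay compound 3 reaches only the assay limit, > 100000 nM, which is the limit noted as the limit of > 100000 nM in this assay, at which 1 of the 3 values shown sits, and not a number. Compound 4 `COc1ccc(/C(C)=N/NC(=S)NC(C)(C)[C@H]2CC=C(C)CC2)cc1` differs from compound 3 by methoxy in place of hydrogen on an aromatic carbon. Among the measured compounds shown here, no measured step touches a methoxy, and the one step known, from compound 1 to compound 2, concerns the aryl itself rather than a substituent on it. With compound 3 at the limit, compound 4 is expected to stay near that limit, with the step that the limit leaves unreadable from compound 3 to compound 4 estimated as little more than scatter. Compound 4 is therefore estimated at 120000 nM, within 30000 nM to 400000 nM.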

Compound 4, concentration for 50% growth inhibition: 90600 nM
Beside the measured number, compound 4's estimate is 1.3-fold (0.12 log units) above it, and the stated range covers the measured number.
By their numbers in this assay, from the lowest: compound 1; then compound 2; then compound 4. At a limit, above all of these: compound 3.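

Phenyl to 4-methoxyphenyl, with the methoxy para to a large group, is the first step shown that adds a substituent to the aryl rather than swapping the aryl, and it reads as an at least 1.1-fold lower number from compound 3 to compound 4 (0.04 log units; that floor lies within the scatter). In this assay compound 4 gives 90600 nM, a measured number that can serve as a reference for further changes at this position. Compound 3 remains a limit and not a number, so the true size of the step cannot be read: the limit of > 100000 nM in this assay, at which 1 of the 4 values shown sits.

From the compounds shown here alone, whether an amine, a hydroxyl or a longer alkoxy chain at this position would shift the number stays open. No pair shown differs only in the methyl on the imine carbon, so its contribution also stays open.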